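Chloro for Methyl in a Sigma Receptor Ligand Series

The source may hold more compounds than are shown below. What is called first, only, known or untested is meant among the compounds shown, and "the series" means these compounds.

Of the compounds shown here, three have been measured in an assay for displacement of a labelled ligand from Sigma non-opioid intracellular receptor 1 (Cavia porcellus); on this read-out lower numbers stand for stronger inhibition and higher numbers for weaker inhibition. Compound 1 `COC(=O)C1(c2ccc(C)cc2)CC1CN1CCN(c2ncccn2)CC1` gives 353 nM, compound 2 `COC(=O)C1(c2ccc(C)cc2)CC1CN1CCN(c2ccccn2)CC1` gives 497 nM, and compound 3 `COC(=O)C1(c2ccccc2)CC1CN1CCC(Cc2ccccc2)CC1` gives 2.2 nM. Among these three numbers compound 1 stands second highest; its nearest neighbour is compound 2, and the step of a 1.4-fold higher number from compound 1 to compound 2 (0.15 log units; within the scatter) lies within the scatter. The values of compound 1 and compound 3 lie far apart, but compound 3 differs from compound 1 in several places at once, so no single change can be read from that gap.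

Compound 4 `COC(=O)C1(c2ccc(Cl)cc2)CC1CN1CCN(c2ncccn2)CC1` has not yet been measured in this assay. It differs from compound 1 by chloro in place of methyl on an aromatic carbon. Going by the values given here, none of the measured steps bears directly on this change: the only step that alters one place, from compound 1 to compound 2, touches the amine nitrogen in a ring rather than the aromatic carbon in question. Among the compounds with values here, with no comparable step available, the account expects no step beyond the scatter from compound 1 to compound 4, that is a 1.0-fold lower number from compound 1 to compound 4 (0.00 log units; within the scatter). Compound 4 is therefore estimated at 350 nM, within a range from 150 nM to 800 nM.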

Compound 4, inhibition constant: 350 nM
Compound 4: middle estimate and measured number agree at the digits printed; low and high end bracket the measured number.
By their numbers in this assay, from the lowest: compound 3; then compounds 4, 1 and 2 (each within the scatter of the next).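

Going by these compounds alone, the step of a 1.0-fold lower number from compound 1 to compound 4 (0.00 log units; within the scatter) is the first reading at this position, and it shows that in this assay 4-chlorophenyl can take the place of 4-methylphenyl on the core of compound 1 with no shift that can be told from the scatter. The earlier step concerned only the group on the amine nitrogen in a ring, so this result extends the picture to a second site: on this core, neither single change shown moves the number beyond the scatter. No measured property is available to explain why this exchange leaves the number where it is.

Going by these compounds, what a methoxy group, a trifluoromethyl group or an amine would do at this aromatic carbon remains open, since a single exchange of one group for another does not describe the tolerance of the position as a whole. Also open, on these data alone, is whether the same exchange would stay within the scatter on a partner with a much lower number, such as compound 3 at 2.2 nM, which differs from compound 1 in several places at once.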